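A few compounds are considered here, and "the series" means these few. Any claim that something is new, unique, unknown or untested is made for them only; others in the source may bear on it.

Compound 3 `CC(C(=O)NCc1ccc(C(F)(F)F)cc1SCc1ccco1)c1ccc(NS(C)(=O)=O)c(F)c1` carries a ((furan-2-yl)methyl)sulfanyl group on its core. In an assay on CHO cells for antagonist activity at transient receptor potential cation channel subfamily V member 1 (Homo sapiens), read by FLIPR (a higher number here means a weaker inhibitor, a lower number a stronger inhibitor), compound 3 gives 3.2 nM, the highest of the three numbers recorded. Its nearest neighbour is compound 2 `CC(C(=O)NCc1ccc(C(F)(F)F)cc1N1CCC(C)(C)CC1)c1ccc(NS(C)(=O)=O)c(F)c1`, which in this assay gives 1.3 nM; furthest away lies compound 1 `CCC1CCN(c2cc(C(F)(F)F)ccc2CNC(=O)C(C)c2ccc(NS(C)(=O)=O)c(F)c2)CC1`, which in this assay gives 0.7 nM. The change from compound 3 to compound 4 `CC(C(=O)NCc1ccc(C(F)(F)F)cc1C1CCCCC1)c1ccc(NS(C)(=O)=O)c(F)c1` is cyclohexyl in place of ((furan-2-yl)methyl)sulfanyl on an aromatic carbon. Within the data shown here, two measured steps touch this position: a 4.6-fold higher number from compound 1 to compound 3 (0.66 log units; beyond the scatter) and a 2.5-fold higher number from compound 2 to compound 3 (0.39 log units; beyond the scatter), both modest and beyond the scatter, and each runs from a ring joined directly to that aromatic carbon to the ((furan-2-yl)methyl)sulfanyl group. The step between those two ring-bearing compounds, a 1.9-fold higher number from compound 1 to compound 2 (0.27 log units; within the scatter), stays within the scatter. Because a 4.6-fold higher number from compound 1 to compound 3 (0.66 log units; beyond the scatter) and a 2.5-fold higher number from compound 2 to compound 3 (0.39 log units; beyond the scatter) both gave higher numbers on moving away from a directly joined ring, compound 4, which brings such a ring back, is expected to show a 2.7-fold lower number from compound 3 to compound 4 (0.43 log units; beyond the scatter). Compound 4 is accordingly estimated at 1.2 nM in this assay, with a range from 0.4 nM to 4 nM.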

Compound 4, inhibition constant: 0.6 nM
Compound 4: middle estimate off by 2.0-fold (0.30 log units), on the high side, and the stated range covers the measured number.
By their numbers in this assay, from the lowest: compounds 4, 1 and 2 (each within the scatter of the next, the first and the last beyond it); then compound 3.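

In this assay, cyclohexyl restores a ring joined directly to the aromatic carbon, giving a 5.3-fold lower number from compound 3 to compound 4 (0.73 log units; beyond the scatter), so compounds 1, 2 and 4 all stand apart from compound 3 with no exception among the four. This ring is carbon only. The result also shows that a ring nitrogen at the point of attachment is not needed for such numbers: a 1.2-fold lower number from compound 1 to compound 4 (0.07 log units; within the scatter) matches the 4-ethylpiperidin-1-yl group, while a 2.2-fold lower number from compound 2 to compound 4 (0.34 log units; beyond the scatter) separates cyclohexyl from the 4,4-dimethylpiperidin-1-yl group. Nothing available explains why these groups differ.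

The compounds shown leave open whether a phenyl ring or an open chain such as a butyl group, joined directly at this carbon, would behave like cyclohexyl. They also cannot separate the sulfur link of compound 3 from its furan ring, since the two change together.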